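Swapping Nitro for Amino, Starting from a Limit

The source may report more compounds than this note shows. Statements on the series, on what has been measured and on what is new or still open speak of the compounds shown alone.

Compound 1 (`O=c1cc(-c2ccc([N+](=O)[O-])cc2)oc2ccc(O)cc12`) has been tested in a functional assay on MCF7 cells (Homo sapiens) for cytotoxicity, read by MTT assay, with a stated time of 6 days; a higher number here means that more compound is needed for the effect, a lower number that less compound is needed. In this assay compound 1 gives > 25 ug/mL, which is a limit of the assay and not a number. Compound 2 (`O=c1cc(-c2ccc([N+](=O)[O-])cc2)oc2cc(O)ccc12`), which also carries a nitro group, gives > 25 ug/mL, and this too is a limit. The whole record so far is therefore (the limit of > 25 ug/mL in this assay, at which 2 of the 2 values shown sit), so compound 1 stands at the limit, with no true number to start from.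

Compound 3 (`Nc1ccc(-c2cc(=O)c3cc(O)ccc3o2)cc1`) keeps the core of compound 1 but has amino in place of nitro on an aromatic carbon, para to a large group: amino in place of nitro on an aromatic carbon. For the measured compounds named here, no measured step shows what such a swap does here, so any forecast is uncertain. A modest move towards less compound being needed seems the likeliest outcome, and compound 3 could also remain at the limit. The estimated change is an at least 1.6-fold lower number from compound 1 to compound 3 (0.22 log units; that floor lies within the scatter). For compound 3 the expected value is 15 ug/mL, with an estimated range from 4 ug/mL to 35 ug/mL.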

Compound 3, concentration for half-maximal effect: > 25 ug/mL
Compound 3 gave a limit, no number (the forecaster's own chance of this, stated with the estimate: 50%); middle value at least 1.6-fold (0.22 log units) from the limit.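

Compound 3 gives > 25 ug/mL, which is a limit of the assay and not a number. For the compounds shown here, compound 1 also stands at a limit, so no step from compound 1 to compound 3 can be read. The record now reads: the limit of > 25 ug/mL in this assay, at which 3 of the 3 values shown sit. Still open, on these data alone, is whether amino in place of nitro changes the concentration needed at all.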